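The source may hold more compounds than are shown below. What is called first, only, known or untested is meant among the compounds shown, and "the series" means these compounds.

Working notes on the series. Compound 1, `CCC(C)(C)Cc1c[nH]c(CCc2ccc(-c3ccc(F)cn3)cc2)n1`, is the starting point for this step. In a functional assay on HEK293 cells for agonist activity at Bombesin receptor subtype-3 (Mus musculus), read by luminescence and calcium flux, with a stated time of 10 min (a lower number here means that less compound is needed, a higher number that more compound is needed for the effect), compound 1 gives 16 nM. Within the data shown here, compound 2, `c1ccc(-c2ccc(CCc3nc(CC4CCCC4)c[nH]3)cc2)nc1`, is the only other measured member; in this assay compound 2 gives 22 nM. Compound 1 has the lower of the two numbers, but the two values lie within the usual scatter of each other, so no ranking between them is read from this pair. Among the measured compounds shown here, no step between measured compounds that differ in one place is available, so the move to compound 3, `CCC(C)(C)Cc1c[nH]c(CCc2ccc(N3CCCCC3)cc2)n1`, has no direct precedent in the data. The change from compound 1 to compound 3 is piperidin-1-yl in place of 5-fluoropyridin-2-yl on an aromatic carbon. Both measured compounds carry an aromatic group at that position, and nothing measured shows what a non-aromatic ring does there. The expected step from compound 1 to compound 3 in this assay is a 3.8-fold higher number from compound 1 to compound 3 (0.57 log units; beyond the scatter), a loss beyond the scatter but with wide uncertainty. For compound 3 in this assay the estimate is 60 nM, with a range from 15 nM to 300 nM.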

Compound 3, half-maximal effective concentration: 28 nM
Beside the measured number, compound 3's estimate is 2.1-fold (0.33 log units) above it, and the stated range covers the measured number.
By their numbers in this assay, from the lowest: compounds 1, 2 and 3 (each within the scatter of the next).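

In this assay, piperidin-1-yl in place of 5-fluoropyridin-2-yl on an aromatic carbon gives a 1.8-fold higher number from compound 1 to compound 3 (0.24 log units; within the scatter), so this position, on a six-membered aromatic ring of carbon only and para to a large group, tolerates a six-membered non-aromatic ring in this pair. The earlier compounds shown here carried only an aromatic group there, so they could not show that an aromatic ring is not needed at this position to stay within the scatter of compound 1. No supporting measurement is available to explain why the two groups give comparable results in this pair.

Open questions remain about how much of the group at this position is needed: a morpholin-4-yl ring, an open-chain diethylamino group or a carboxylic acid would each test a different part of that question. On these data alone, it also remains open whether piperidin-1-yl behaves the same way when the core carries the cyclopentylmethyl group of compound 2 rather than the side chain of compound 1.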